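Swapping methyl for methoxy on a potent antiproliferative aryl series

A few compounds are considered here, and "the series" means these few. Any claim that something is new, unique, unknown or untested is made for them only; others in the source may bear on it.

Of the compounds shown here, three sharing one core have been tested in a functional assay on CCRF-CEM cells (Homo sapiens) for antiproliferative activity; on this read-out lower numbers stand for stronger inhibition and higher numbers for weaker inhibition. Compound 1 `COc1cc(C(=O)c2sc(-c3ccc(-c4ccccc4)cc3)cc2N)cc(OC)c1OC` gives > 10000 nM, and this value is a limit of the assay, not a number. Compound 2 `COc1cc(C(=O)c2sc(-c3ccc(F)cc3)cc2N)cc(OC)c1OC` gives 15 nM. Compound 3 `COc1cc(C(=O)c2sc(-c3ccc(C)cc3)cc2N)cc(OC)c1OC` gives 15 nM, so it stands level with compound 2, as the step shows: no change at the digits printed from compound 2 to compound 3 (within the scatter).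

The next compound, compound 4 `COc1ccc(-c2cc(N)c(C(=O)c3cc(OC)c(OC)c(OC)c3)s2)cc1`, turns 4-methylphenyl into 4-methoxyphenyl, with methoxy in place of methyl on an aromatic carbon, para to a large group: methoxy in place of methyl on an aromatic carbon.

Two measured steps show that this position can matter greatly. With fluoro in place of phenyl the result is an at least 660-fold lower number from compound 1 to compound 2 (2.82 log units; beyond the scatter), and with methyl in place of phenyl it is an at least 660-fold lower number from compound 1 to compound 3 (2.82 log units; beyond the scatter). Both remove phenyl, however, and compound 3 has no phenyl at this position to lose. The closer precedent is the exchange of one small group for another in compound 3, where the step was no change at the digits printed from compound 2 to compound 3 (within the scatter). No step beyond the scatter is therefore expected, though one exchange is thin evidence and a modest weakening remains possible.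

The expected step is a 1.3-fold higher number from compound 3 to compound 4 (0.12 log units; within the scatter). For compound 4 the estimated value in this assay is 20 nM, with an expected range from 6 nM to 100 nM.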

Compound 4, half-maximal inhibitory concentration: 19 nM
The estimate for compound 4 lay 1.1-fold (0.02 log units) above the measured number; the range from low to high includes it.
By their numbers in this assay, from the lowest: compounds 2, 3 and 4 (each within the scatter of the next). At a limit, above all of these: compound 1.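

In this assay, the change from 4-methylphenyl to 4-methoxyphenyl brings in an oxygen and a hydrogen-bond acceptor, and the read-out still gives a 1.3-fold higher number from compound 3 to compound 4 (0.10 log units; within the scatter). Going by these compounds alone, the exchange of methoxy for fluoro reads the same way, with a 1.3-fold higher number from compound 2 to compound 4 (0.10 log units; within the scatter), so fluoro, methyl and methoxy all sit within the scatter of one another at this position, where the earlier compounds offered only the single comparison of fluoro with methyl. Methoxy also keeps the wide separation from the phenyl-bearing end of the series, with an at least 520-fold lower number from compound 1 to compound 4 (2.72 log units; beyond the scatter), so the sharp loss seen so far belongs to phenyl alone among the four groups shown.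

As far as these compounds go, compound 1 gives a limit of the assay and not a number, so the full size of that separation stays open: the limit of > 10000 nM in this assay, at which 1 of the 4 values shown sits. From the compounds shown here alone, what an ethoxy group, a dimethylamino group or a carboxylic acid would give at this position also remains open, as does the point between methoxy and phenyl at which the read-out gives way.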